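The source may hold more compounds than are shown below. What is called first, only, known or untested is meant among the compounds shown, and "the series" means these compounds.

Measured compounds in an assay on isolated protein for inhibition of ribosomal protein S6 kinase alpha-2 (Homo sapiens), read by fluorescence, with a stated time of 20 min, tested at 10 uM; a lower number here means less inhibition, a higher number more inhibition at the concentration tested (going by the name of the read-out):

compound 1, `CCOc1ccc(NCN2C(=O)c3ccc([N+](=O)[O-])cc3C2=O)cc1`, in this assay gives 87%
compound 2, `COc1ccc(NCN2C(=O)c3ccc(NC(=O)c4ccccc4)cc3C2=O)cc1`, in this assay gives 82%

Both measured compounds share the same core and the same aminomethyl link to a 4-alkoxyphenyl group; they differ at the substituent on the core (nitro in compound 1, benzamido in compound 2) and in the alkoxy group (ethoxy in compound 1, methoxy in compound 2). Compound 2 has the lower of the two numbers, but the two values lie within the usual scatter of each other, so no order between compound 1 and compound 2 can be read from them. Going by the values given here, no single-point step between measured compounds is available, so there is no direct reference for the size of a small change at the alkoxy group.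

Compound 3, `CCOc1ccc(NCN2C(=O)c3ccc(NC(=O)c4ccccc4)cc3C2=O)cc1`, keeps the benzamido substituent of compound 2 and changes only the alkoxy group. The difference is methyl in place of hydrogen on a saturated chain carbon bound to an oxygen on an aromatic ring. The step from compound 2 to compound 3 is expected to be small in this assay, without a clear direction and not beyond the scatter, as the estimated step of a number 1 percentage points higher from compound 2 to compound 3 (within the scatter) shows. Compound 3 is therefore expected to give about 83%, within a range from 72% to 92%.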

Compound 3, a percentage reported as inhibition, at one concentration (the size of the read-out at that concentration, not a potency): 69.5%
Compound 3: middle estimate off by 13.5 percentage points, on the high side; the whole stated range lies above it.
By their numbers in this assay, from the lowest: compound 3; then compounds 2 and 1 (each within the scatter of the next).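

In this assay, the alkoxy group now has a direct reading: with benzamido held on the core, methoxy to ethoxy gives a number 12.5 percentage points lower from compound 2 to compound 3 (beyond the scatter) and shows that one added methyl at this place can move the number by more than the scatter. With ethoxy held, the substituent on the core also gets its own reading, as benzamido in place of nitro gives a number 17.5 percentage points lower from compound 1 to compound 3 (beyond the scatter) in a comparison that the earlier pair, differing in two places, could not provide. No measurement shown here bears on the cause of either step.

On these data alone, each step rests on a single pair, so it remains open whether methoxy to ethoxy gives a similar step with nitro on the core, and whether benzamido in place of nitro gives a similar step with methoxy on the phenyl group. As far as these compounds go, it also remains open how the number runs with a longer chain such as propoxy at this place, or with a hydroxyl group in place of the alkoxy group.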